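The source may hold more compounds than are shown below. What is called first, only, known or untested is meant among the compounds shown, and "the series" means these compounds.

Among the measured compounds shown here, compound 2 `Nc1ccccc1NC(=O)c1ccc(Cn2cnc3c(Nc4cccc(OC(F)(F)F)c4)nc(Cl)nc32)cc1` gives 46.6% in a functional assay on HCT-116 cells (Homo sapiens) for antiproliferative activity, read by CCK-8 assay, with a stated time of 72 h, tested at 8 uM (on this read-out lower numbers stand for a weaker effect and higher numbers for a stronger effect at the one concentration tested), the higher of the two numbers measured so far; its nearest neighbour, compound 1 `Nc1ccccc1NC(=O)/C=C/c1ccc(Cn2cnc3c(Nc4cccc(OC(F)(F)F)c4)nc(Cl)nc32)cc1`, gives 5.23%, a step of a number 41.4 percentage points higher from compound 1 to compound 2 (beyond the scatter). Compound 3 `CN1CCN(c2nc(Cl)nc3c2ncn3Cc2ccc(C(=O)Nc3ccccc3N)cc2)CC1` differs from compound 2 at a different place in the molecule: 4-methylpiperazin-1-yl in place of (3-(trifluoromethoxy)phenyl)amino on an aromatic carbon. For the measured compounds named here, no measured step covers this exchange, since the single measured step concerns a different part of the molecule, so the size and direction of a number 16.6 percentage points lower from compound 2 to compound 3 (beyond the scatter) can be expected only loosely. Compound 3 is therefore estimated at 30%, within a wide range from 5% to 60%.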

Compound 3, a percentage reported as inhibition, at one concentration (the size of the read-out at that concentration, not a potency): 72.8%
For compound 3 the middle estimate is 42.8 percentage points below the measured one; measured number above the stated range.
By their numbers in this assay, from the lowest: compound 1; then compound 2; then compound 3.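

Swapping (3-(trifluoromethoxy)phenyl)amino for 4-methylpiperazin-1-yl on the shared core changes the result in this assay (a number 26.2 percentage points higher from compound 2 to compound 3 (beyond the scatter)). This position therefore accepts a non-aromatic ring with no hydrogen-bond donor in place of an aromatic amine, and in this pair the aryl group and its amine hydrogen are not needed for the effect. Nothing measured explains the rise. Open, going by these compounds, is whether the ring nitrogen's methyl group matters, as an unsubstituted piperazine would show. Also open, on these data alone, is whether morpholine, which has oxygen in place of that nitrogen, would do as well.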